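Swapping the Butoxy Tail for a Benzyloxy Group

A few compounds are considered here, and "the series" means these few. Any claim that something is new, unique, unknown or untested is made for them only; others in the source may bear on it.

Compound 2 `CCCCOc1ccc(-c2c(C)[nH]c(=O)n2C)cc1` is the anchor of this comparison. In a functional assay on brain (Rattus norvegicus, strain Wistar) for inhibition (a lower number here means a stronger inhibitor, a higher number a weaker inhibitor), compound 2 gives 5100 nM, the lowest of the two numbers that have actually been measured. Compound 1 `Cc1[nH]c(=O)n(C)c1-c1ccccc1` carries a hydrogen where compound 2 carries the butoxy group. In this assay compound 1 reaches only a limit of the assay, namely > 100000 nM. The step between them, an at least 19-fold lower number from compound 1 to compound 2 (1.29 log units; beyond the scatter), is therefore read against that limit (the limit of > 100000 nM in this assay, at which 1 of the 3 values shown sits). Compound 3 `CCCCOc1ccc(-c2c(C)[nH]c(=O)n2C2CCCCC2)cc1` gives 13900 nM in this assay, and the step of a 2.7-fold higher number from compound 2 to compound 3 (0.44 log units; beyond the scatter) is a modest loss.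

Compound 4 `Cc1[nH]c(=O)n(C)c1-c1ccc(OCc2ccccc2)cc1` has not been measured. Relative to compound 2 the change is phenyl in place of propyl on a saturated chain carbon bound to an oxygen on an aromatic ring. Neither measured step alters this end of the chain: the large step of an at least 19-fold lower number from compound 1 to compound 2 (1.29 log units; beyond the scatter) shows that the butoxy region matters, while a 2.7-fold higher number from compound 2 to compound 3 (0.44 log units; beyond the scatter) concerns the nitrogen. Within the data shown here, with no direct precedent, a step of modest size in either direction, possibly within the scatter, is expected, so for compound 4 the step of a 1.5-fold lower number from compound 2 to compound 4 (0.16 log units; within the scatter) is the estimate. Compound 4 is expected to give about 3500 nM in this assay, within a range from 900 nM to 14000 nM.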

Compound 4, half-maximal inhibitory concentration: 6700 nM
For compound 4 the middle estimate is 1.9-fold (0.28 log units) below the measured one; the range from low to high includes it.
By their numbers in this assay, from the lowest: compounds 2 and 4 (each within the scatter of the next); then compound 3. At a limit, above all of these: compound 1.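

The step of a 1.3-fold higher number from compound 2 to compound 4 (0.12 log units; within the scatter) shows that, in this assay, a bulkier tail end that carries a ring does not move the number beyond the scatter: butyl gives way to benzyl, and phenyl with its six-membered aromatic ring of carbon replaces propyl on the saturated chain carbon bound to the oxygen. So this end of the tail accepts both a straight chain and an aromatic ring, at least for these two groups. Compound 1, which has hydrogen in place of the whole tail, stands only at a limit, > 100000 nM, and nothing shown explains why butyl and benzyl read alike.

Going by these compounds, it remains open whether an amine or a carboxylic acid at the tail end, or a longer chain, would keep the number in this range. On these data alone, it also remains open whether cyclohexyl on the aromatic nitrogen would change the number for a benzyl tail as it does for a butyl tail.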